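Three Amide Analogues Sit at the Cytotoxicity Limit

The source may report more compounds than this note shows. Statements on the series, on what has been measured and on what is new or still open speak of the compounds shown alone.

Measured compounds and their values in an ADME assay on HEK293 cells (Homo sapiens) for cytotoxicity, read by CellTiter-Glo and resazurin assay, with a stated time of 72 h; on this read-out higher numbers stand for an effect only at larger amounts of compound and lower numbers for an effect already at smaller amounts:
- compound 1, `CCOC(=O)CCCCCOc1cccc(CN(C(=O)c2ccc(-c3cccc(-c4ccccc4)c3)cc2)C(C)C)c1`: > 26000 nM, a limit of the assay, not a number
- compound 2, `CCOC(=O)CCCCCOc1cccc(CN(C(=O)c2ccc(-c3cnc(OC)nc3OC)cc2)C(C)C)c1`: > 26000 nM, a limit of the assay, not a number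
- compound 3, `CCOC(=O)CCCCCOc1cccc(CN(C(=O)c2ccc(-c3ccco3)cc2)C(C)C)c1`: > 26000 nM, a limit of the assay, not a number

Compound 3 stands where all three measured compounds stand: at the limit of > 26000 nM in this assay, at which 3 of the 3 values shown sit. The steps a step that the two limits leave unreadable from compound 1 to compound 2, a step that the two limits leave unreadable from compound 1 to compound 3 and a step that the two limits leave unreadable from compound 2 to compound 3 are therefore unreadable; none of them shows a difference between the three aryl groups.

Compound 4, `CCOC(=O)CCCCCOc1cccc(CN(C(=O)c2ccc(-c3ccc4c(c3)OCCO4)cc2)C(C)C)c1`, differs from compound 3 in one place: 2,3-dihydro-1,4-benzodioxin-6-yl in place of furan-2-yl on an aromatic carbon. Among the measured compounds shown here, no measured step speaks to this change, since every step among compounds 1, 2 and 3 is hidden by the limit. Three different aryl groups on the same carbon all gave only a limit, so compound 4 is expected to give a limit as well in this assay, with the expected step that the limit leaves unreadable from compound 3 to compound 4 lying within the scatter. Compound 4 is estimated at 30000 nM, ranging from 13000 nM to 100000 nM.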

Compound 4, half-maximal effective concentration: > 24400 nM
Compound 4: no number, only a limit (the forecaster's own chance of this, stated with the estimate: 85%); the middle value is on the limit's open side.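

In this assay compound 4 gives > 24400 nM, a limit of the assay and not a number. Among the compounds shown here, compound 1, compound 2 and compound 3 also gave only limits, so no step from any of them to compound 4 can be read. The compounds shown leave open whether these aryl groups differ at all in cytotoxicity, and at what concentration any of the four would show an effect.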